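The source may report more compounds than this note shows. Statements on the series, on what has been measured and on what is new or still open speak of the compounds shown alone.

Measured so far in an assay on cells for antagonist activity at transient receptor potential cation channel subfamily V member 1 (Homo sapiens), read by FLIPR and calcium flux, with a stated time of 6 min; on this read-out higher numbers stand for weaker inhibition and lower numbers for stronger inhibition: compound 1 `CC(C(=O)NCc1ccc(C(C)(C)C)nc1N1CCCCCC1)c1ccc(NS(C)(=O)=O)c(F)c1` gives 0.9 nM; compound 2 `CC(C(=O)NCc1ccc(C(C)(C)C)cc1N1CCCC1)c1ccc(NS(C)(=O)=O)c(F)c1` gives 8.1 nM; compound 3 `CC(C(=O)NCc1ccc(C(C)(C)C)cc1N1CCCCC1)c1ccc(NS(C)(=O)=O)c(F)c1` gives 1.9 nM.

Compound 3 stands second highest of the three numbers, between compound 1 and compound 2. Within the data shown here, the one step measured at this position is a 4.3-fold lower number from compound 2 to compound 3 (0.63 log units; beyond the scatter), a change from one ring to a larger ring. Compound 4 `CCCCCCOc1cc(C(C)(C)C)ccc1CNC(=O)C(C)c1ccc(NS(C)(=O)=O)c(F)c1` carries a different kind of change: hexyloxy in place of piperidin-1-yl on an aromatic carbon. Among the measured compounds shown here, no measured step swaps a ring for a chain here, so the earlier step says only that this position tolerates change at a modest scale. A modest weakening is therefore expected in this assay. Compound 4 is estimated at 4 nM, with a range from 1 nM to 20 nM. That estimate means a step of a 2.1-fold higher number from compound 3 to compound 4 (0.32 log units; beyond the scatter).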

Compound 4, inhibition constant: 0.5 nM
Estimate against measurement, compound 4: 8.0-fold (0.90 log units) above; the measured number lies below the stated range.
By their numbers in this assay, from the lowest: compounds 4 and 1 (each within the scatter of the next); then compound 3; then compound 2.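

In this assay, this position is not limited to a ring: putting the open hexyloxy chain in place of piperidin-1-yl gives a 3.8-fold lower number from compound 3 to compound 4 (0.58 log units; beyond the scatter), and putting it in place of pyrrolidin-1-yl gives a 16-fold lower number from compound 2 to compound 4 (1.21 log units; beyond the scatter). A ring at this aromatic carbon is therefore not needed for a low number. Nothing available explains why the chain gives these steps.

From the compounds shown here alone, whether a shorter chain such as butoxy would keep the number this low remains open. So does the role of the oxygen, which a plain heptyl chain would test.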